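Compound 3: 2-hydroxyphenyl in place of 4-methylphenyl

The compounds below may be only part of what the source reports. "The series", "measured", "known", "first", "only" and "open" are said of these compounds alone.

In a functional assay on OVCAR-3 cells (Homo sapiens) for inhibition, read by MTT assay, with a stated time of 24 h (a lower number here means a stronger inhibitor, a higher number a weaker inhibitor), compound 1 `CC1(C)[C@H]2CC[C@]1(C)N(Cc1cn(-c3ccc(Br)cc3)nn1)C(=O)C2` gives 140 nM as its value, while compound 2 `Cc1ccc(-n2cc(CN3C(=O)C[C@@H]4CC[C@@]3(C)C4(C)C)nn2)cc1` gives 40 nM and holds the lower of the two numbers, which makes it the stronger inhibitor of this pair. Compound 3 `CC1(C)[C@H]2CC[C@]1(C)N(Cc1cn(-c3ccccc3O)nn1)C(=O)C2` keeps the shared core but carries a different group on an aromatic nitrogen of a five-membered aromatic ring with 3 nitrogen: 2-hydroxyphenyl in place of 4-methylphenyl on an aromatic nitrogen describes the swap of 4-methylphenyl for 2-hydroxyphenyl. For the measured compounds named here, only one measured step bears on this: a 3.5-fold lower number from compound 1 to compound 2 (0.54 log units; beyond the scatter) with methyl in place of bromo on an aromatic carbon. Going by the values given here, no measured compound carries a hydroxy group, so that step offers thin evidence, and only of size. With compound 2 at 40 nM as the lower of just two values, a modest rise in this assay of similar size is expected rather than a further drop, though the direction remains uncertain. The expected change is a 2.5-fold higher number from compound 2 to compound 3 (0.40 log units; beyond the scatter) in size. Compound 3 is estimated at 100 nM with an expected range from 30 nM to 350 nM as its likely span.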

Compound 3, half-maximal inhibitory concentration: 90 nM
Compound 3: middle estimate off by 1.1-fold (0.05 log units), on the high side; measured number inside the range.
By their numbers in this assay, from the lowest: compound 2; then compounds 3 and 1 (each within the scatter of the next).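

At this position, on an aromatic nitrogen of a five-membered aromatic ring with 3 nitrogen, the change to 2-hydroxyphenyl brings in 1 hydrogen-bond donor and 1 hydrogen-bond acceptor, where 4-methylphenyl has 0 of each, and in this assay it gives a 2.3-fold higher number from compound 2 to compound 3 (0.35 log units; beyond the scatter), so compound 2 stays the strongest inhibitor of the three. For the compounds shown here, the earlier pair showed only one group on the aromatic ring exchanged for another, whereas the comparison with the bromo compound now gives a 1.6-fold lower number from compound 1 to compound 3 (0.19 log units; within the scatter), a step that leaves 2-hydroxyphenyl and 4-bromophenyl indistinguishable in this read-out despite their different groups. Nothing available explains why the number moves with this change at this position.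

Since 2-hydroxyphenyl differs from 4-methylphenyl both in its group and in where that group sits on the aromatic ring, the three compounds cannot separate what the hydroxy group contributes from what its placement contributes. They also leave open how a methoxy group in place of the hydroxy group, or an amine or a carboxylic acid on the same aromatic ring, would read in this assay.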